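Methoxy in Place of Hydrogen on the Core of Compound 1

This account rests on a few compounds, and the source may have more. Where it says the series, first, only, none or still open, it means among the compounds named here.

Of the compounds shown here, three sharing one core have been measured in an ADME assay on GM00637 cells (Homo sapiens) for cytotoxicity, read by MTT assay, with a stated time of 72 h; a lower number here means a stronger inhibitor, a higher number a weaker inhibitor. Compound 1 `O=c1ccc2nc(-c3ccccc3)nn(-c3ccccc3)c-2c1` is the parent without a substituent on the carbon ring in question; in this assay compound 1 gives 230 nM, the lowest of the three numbers. Compound 2 `CNc1cc2nc(-c3ccccc3)nn(-c3ccccc3)c-2cc1=O` carries a methylamino group on an aromatic carbon, and in this assay compound 2 gives 930 nM. Compound 3 `CCN(CC)c1cc2nc(-c3ccccc3)nn(-c3ccccc3)c-2cc1=O` carries a diethylamino group on that carbon, and in this assay compound 3 gives 2730 nM. Both additions raise the number: a 4.0-fold higher number from compound 1 to compound 2 (0.61 log units; beyond the scatter) and a 12-fold higher number from compound 1 to compound 3 (1.07 log units; beyond the scatter), and the move from one amine to the other is a 2.9-fold higher number from compound 2 to compound 3 (0.47 log units; beyond the scatter).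

Compound 4 `COc1cc2nc(-c3ccccc3)nn(-c3ccccc3)c-2cc1=O` has not yet been measured. It differs from compound 1 as follows: methoxy in place of hydrogen on an aromatic carbon The two earlier steps from compound 1 bear on this change, since each also replaces hydrogen at the same carbon with a small group. The closer comparison is a 4.0-fold higher number from compound 1 to compound 2 (0.61 log units; beyond the scatter), while a 12-fold higher number from compound 1 to compound 3 (1.07 log units; beyond the scatter) marks the outer edge of what such an addition has cost. The expected step is therefore a 3.0-fold higher number from compound 1 to compound 4 (0.48 log units; beyond the scatter), a modest rise beyond the scatter. The estimate for compound 4 in this assay is 700 nM, with a likely range from 300 nM to 1800 nM.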

Compound 4, half-maximal inhibitory concentration: > 5000 nM
Compound 4 gave a limit, no number (the forecaster's own chance of this, stated with the estimate: 3%); at least 7.1-fold (0.85 log units) between middle value and limit.
By their numbers in this assay, from the lowest: compound 1; then compound 2; then compound 3. At a limit, above all of these: compound 4.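

In this assay, compound 4 gives a limit of the assay and not a number: the limit of > 5000 nM in this assay, at which 1 of the 4 values shown sits. Even so, the limit fixes a floor for the step, an at least 21-fold higher number from compound 1 to compound 4 (1.33 log units; beyond the scatter), which shows that on this aromatic carbon, a methoxy group of only 2 heavy atoms can raise the number by a large margin, a result that the two amino groups alone could not have shown. Against those amino compounds, the step of an at least 5.3-fold higher number from compound 2 to compound 4 (0.73 log units; beyond the scatter) clearly separates methoxy from methylamino, whereas the step of an at least 1.8-fold higher number from compound 3 to compound 4 (0.26 log units; that floor lies within the scatter) does not firmly separate methoxy from diethylamino, so the data show that an oxygen-linked group on this carbon does not have to stay close to the parent or to the methylamino compound.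

Going by these compounds, how far the true value of compound 4 lies past its limit stays unknown, so the real size of all three steps remains open. On these data alone, with one oxygen-linked group in view, it also remains open whether a hydroxyl group or a longer ether such as ethoxy on this carbon would follow compound 4 or stay nearer compound 1.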